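Compound 3 to compound 4: a 2-methoxyethoxy group enters

The source may hold more compounds than are shown below. What is called first, only, known or untested is meant among the compounds shown, and "the series" means these compounds.

Of the compounds shown here, three have been read so far in a physicochemical assay for solubility, read by chemiluminescence, measured as kinetic solubility; on this read-out lower numbers stand for lower solubility and higher numbers for higher solubility. Compound 1 `Cn1ncc2c(NS(=O)(=O)c3cccc(Cl)c3Cl)cccc21` gives 170000 nM. Compound 2 `Cn1ncc2c(NS(=O)(=O)c3cccc(Cl)c3Cl)ccnc21` returns only a limit, >= 310000 nM. Compound 3 `Cn1ncc2c(NS(=O)(=O)c3cccc(Cl)c3Cl)ncnc21` gives 476000 nM, the higher of the two actual numbers and beyond the scatter from the reading for compound 1.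

The next compound to be read is compound 4 `COCCOc1nn(C)c2ncnc(NS(=O)(=O)c3cccc(Cl)c3Cl)c12`. It keeps the core of compound 3 and carries 2-methoxyethoxy in place of hydrogen on an aromatic carbon of the five-membered aromatic ring with 2 nitrogen: 2-methoxyethoxy in place of hydrogen on an aromatic carbon. Going by the values given here, no two measured compounds differ in one place only, so no measured step shows directly what this change does in this assay.

The expectation therefore rests on where the starting point lies. Among the compounds with values here, with compound 3 at 476000 nM, the top number so far, there is more room for a fall than for a rise. A moderate downward step is expected, although a result within the scatter would not be surprising. The expected move is a 1.9-fold lower number from compound 3 to compound 4 (0.28 log units; within the scatter). Compound 4 is estimated at 250000 nM, with an expected range of 90000 nM to 500000 nM.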

Compound 4, solubility: >= 463000 nM
Compound 4: a limit, no number; the forecaster's own chance of this, stated with the estimate: 20%; middle value at least 1.8-fold (0.26 log units) away from the limit.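

In this assay compound 4 gives >= 463000 nM, which is a limit and not a number, so the change from compound 3 to compound 4 cannot be read as a step. The compounds shown leave open what 2-methoxyethoxy in place of hydrogen on an aromatic carbon does to this read-out, including whether it moves it at all.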